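Swapping nitro for methyl on the ester's aromatic ring

The source may hold more compounds than are shown below. What is called first, only, known or untested is meant among the compounds shown, and "the series" means these compounds.

Compound 1 `COc1ccc(C(=O)Oc2cc3c(C)ccc(C(C)C)c3cc2C)cc1`: 42.6%
Compound 2 `CC1=CC[C@H](C(C)C)c2cc(C)c(OC(=O)c3ccc([N+](=O)[O-])cc3)cc21`: 16.8%
Compound 3 `Cc1cc2c(C(C)C)ccc(C)c2cc1OC(=O)c1ccc([N+](=O)[O-])cc1`: 100%

Of the compounds shown here, three have been measured in a functional assay on U-251 cells (Homo sapiens) for antiproliferative activity, read by sulforhodamine B assay, with a stated time of 48 h, tested at 50 uM; on this read-out higher numbers stand for more inhibition at the one concentration tested (going by the name of the read-out) and lower numbers for less inhibition. Compound 2 stands lowest of the three; compound 1 lies above it and compound 3 highest, both gaps beyond the scatter. Compound 4 `CC1=CC[C@H](C(C)C)c2cc(C)c(OC(=O)c3ccc(C)cc3)cc21` differs from compound 2 by methyl in place of nitro on an aromatic carbon. For the measured compounds named here, the one measured step that bears on this is a number 57.4 percentage points higher from compound 1 to compound 3 (beyond the scatter), a large rise when nitro replaced methoxy on the shared core of those two compounds. Removing the nitro from compound 2 is therefore expected to lower the number, though a floor near zero limits how far it can fall. For compound 4 the expected step is a number 8.8 percentage points lower from compound 2 to compound 4 (within the scatter). Compound 4 is estimated at 8%, within 0% to 28%.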

Compound 4, a percentage reported as inhibition, at one concentration (the size of the read-out at that concentration, not a potency): 67.7%
Estimate against measurement, compound 4: 59.7 percentage points below; the whole stated range lies below it.
By their numbers in this assay, from the lowest: compound 2; then compound 1; then compound 4; then compound 3.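

On the core of compound 2, the group at this position, para to a large group, weighs heavily: in this assay, methyl in place of nitro gives a number 50.9 percentage points higher from compound 2 to compound 4 (beyond the scatter) on a single swap. Nitro therefore does not raise the number on every core, although the earlier step, a number 57.4 percentage points higher from compound 1 to compound 3 (beyond the scatter) when nitro replaced methoxy, had suggested it might. From the compounds shown here alone, whether an amine or methoxy at this position on the core of compound 2 would read nearer compound 2 or compound 4 stays open. No measurement at hand explains why nitro behaves so differently on the two cores.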